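Cyclohexyl in place of phenyl: estimate for compound 3

The source may report more compounds than this note shows. Statements on the series, on what has been measured and on what is new or still open speak of the compounds shown alone.

Compound 2 `Cc1nc(N)sc1CCCNC(=N)NC(=O)C[C@H](C)c1ccccc1` gives 87% in a functional assay on cardiac atrium for agonist activity at histamine H2 receptor (Cavia porcellus) (on this read-out lower numbers stand for smaller maximal responses and higher numbers for larger maximal responses), the higher of the two values; compound 1 `Cc1nc(N)sc1CCCNC(=N)NC(=O)C[C@@H](C)c1ccccc1` gives 73%. Among the compounds with values here, the only measured step, a number 14 percentage points higher from compound 1 to compound 2 (beyond the scatter), is a change of configuration alone. Compound 3 `Cc1nc(N)sc1CCCNC(=N)NC(=O)C[C@@H](C)C1CCCCC1` carries 1-cyclohexylethyl in place of 1-phenylethyl on a saturated chain carbon bound to a carbonyl carbon. Within the data shown here, no measured step concerns a ring change of this kind, so the step from compound 2 to compound 3 has no direct precedent, and the expected step of a number 2 percentage points lower from compound 2 to compound 3 (within the scatter) is not beyond the scatter. Compound 3 is therefore expected to give 85%, within a range from 65% to 100%.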

Compound 3, largest response reached (Emax), in percent of the reference or control that the assay uses: 80%
For compound 3 the middle estimate is 5 percentage points above the measured one, and the stated range covers the measured number.
By their numbers in this assay, from the lowest: compounds 1, 3 and 2 (each within the scatter of the next, the first and the last beyond it).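

In this assay an aromatic ring is not needed at this place for a large maximal response, as the change from phenyl to cyclohexyl shows (a number 7 percentage points higher from compound 1 to compound 3 (within the scatter)) and the change from 1-phenylethyl to 1-cyclohexylethyl confirms (a number 7 percentage points lower from compound 2 to compound 3 (within the scatter)). Compound 3 thus cannot be told apart from either compound 1 or compound 2, although those two differ beyond the scatter. Nothing at hand bears on the reason for these numbers.

From the compounds shown here alone, whether the opposite configuration of 1-cyclohexylethyl changes the response remains open. So does the response with an amine, a carboxylic acid or a longer chain in place of this ring.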